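Compound 2 to compound 3: a new amide substituent

The compounds below may be only part of what the source reports. "The series", "measured", "known", "first", "only" and "open" are said of these compounds alone.

In an ADME assay on HepG2 cells (Homo sapiens) for cytotoxicity, read by trypan blue exclusion, with a stated time of 48 h, in the presence of a further agent that is not named here (on this read-out lower numbers stand for higher toxicity in this test and higher numbers for lower toxicity in this test), compound 1 `COc1ccc2nc(C)cc(OCC(=O)Nc3ccc(Br)cc3)c2c1` is reported only as a limit, > 125000 nM. For the measured compounds named here, compound 2 `COc1ccc2nc(C)cc(OCC(=O)Nc3ccc(Cl)cc3)c2c1` gives 71100 nM, the only true number so far, so its standing cannot yet be judged against a second number. Going by the values given here, the one measured step is an at least 1.7-fold lower number from compound 1 to compound 2 (0.24 log units; that floor lies within the scatter), and it concerns only chloro in place of bromo on an aromatic carbon. The top of the measured range is marked by the limit of > 125000 nM in this assay, at which 1 of the 2 values shown sits.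

The next compound is compound 3 `COc1ccc2nc(C)cc(OCC(=O)NCCCc3ccccc3)c2c1`, and the change is 3-phenylpropyl in place of 4-chlorophenyl on an amide-type nitrogen. Among the compounds with values here, no measured step covers a change on the amide-type nitrogen, so the chloro-for-bromo step offers only weak guidance here. The expectation therefore stays anchored on compound 2 at 71100 nM, with no step beyond the scatter expected in this assay in either direction. The estimated change is a 1.0-fold lower number from compound 2 to compound 3 (0.01 log units; within the scatter), and the uncertainty is wide. For compound 3 the expected half-maximal cytotoxic concentration is 70000 nM, with an estimated range of 25000 nM to 125000 nM.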

Compound 3, half-maximal cytotoxic concentration: 50700 nM
Compound 3: middle estimate off by 1.4-fold (0.14 log units), on the high side, within the range that was stated.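

In this assay, for the compounds shown here, the first measured change on the amide-type nitrogen, 3-phenylpropyl in place of 4-chlorophenyl, gives a 1.4-fold lower number from compound 2 to compound 3 (0.15 log units; within the scatter), so on this pair the exchange of a ring-bearing aromatic substituent for a ring-bearing chain does not move the half-maximal cytotoxic concentration by more than the usual scatter. Going by these compounds alone, with 3-phenylpropyl in place of 4-bromophenyl at the same nitrogen, the reading is an at least 2.4-fold lower number from compound 1 to compound 3 (0.39 log units; beyond the scatter), the first step that clears the scatter, although it gives only a minimum size and the two steps at this nitrogen rest on different halogen-bearing starting points. Compound 1 is held at a limit, so the full size of that step stays unknown: the limit of > 125000 nM in this assay, at which 1 of the 3 values shown sits.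

Still open, as far as these compounds go, is whether a shorter benzyl group or a longer 5-phenylpentyl chain on the amide-type nitrogen would give a step beyond the scatter from compound 3. Equally open, from the compounds shown here alone, is how an amine or a carboxylic acid at the end of the 3-phenylpropyl chain would read in this assay.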